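Allyloxy for trifluoroethoxy: expected cytotoxicity of compound 4

The source may report more compounds than this note shows. Statements on the series, on what has been measured and on what is new or still open speak of the compounds shown alone.

The series keeps one core, shown as `CCCCSc1nc(N)nc2c1ncn2/C=C1/CC1(CO)CO` for compound 1, and varies the group on the aromatic carbon. In an ADME assay on CCRF-HSB-2 cells (Homo sapiens) for cytotoxicity, with a stated time of 7 days (a higher number here means that more compound is tolerated, a lower number that less compound is tolerated), compound 1 gives 89000 nM. Compound 2 `Nc1nc(OCC(F)(F)F)c2ncn(/C=C3/CC3(CO)CO)c2n1` carries 2,2,2-trifluoroethoxy in that place; in this assay compound 2 reaches only the limit of > 20000 nM, so for compound 2 there is a limit and no number. Compound 3 `Nc1nc(NC2CCCC2)c2ncn(/C=C3/CC3(CO)CO)c2n1` also returns only the limit of > 20000 nM in this assay. Accordingly the steps a step that the limit leaves unreadable from compound 1 to compound 2 and a step that the limit leaves unreadable from compound 1 to compound 3 cannot be sized, and neither can a step that the two limits leave unreadable from compound 2 to compound 3, because of the limit of > 20000 nM in this assay, at which 2 of the 3 values shown sit. What the three values do show is that compound 1 tolerates less compound than either compound 2 or compound 3 on the numbers seen.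

Compound 4 `C=CCOc1nc(N)nc2c1ncn2/C=C1/CC1(CO)CO` differs from compound 2 by vinyl in place of trifluoromethyl on a saturated chain carbon bound to an oxygen on an aromatic ring. Going by the values given here, no measured step covers this change; the nearest information is that the variations so far among compound 1, compound 2 and compound 3 either leave the read-out at the limit or move it away from compound 1. Compound 4 is therefore expected to stay at or near the limit, with an estimated value of 40000 nM in a range from 15000 nM to 150000 nM. The expected step that the limit leaves unreadable from compound 2 to compound 4 is estimated as no change beyond the scatter, most likely reported again as a limit.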

Compound 4, half-maximal cytotoxic concentration: > 20000 nM
Compound 4: no number, only a limit; the forecaster's own chance of this, stated with the estimate: 65%; the middle value is on the limit's open side.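

In this assay compound 4 gives > 20000 nM, a limit and not a number. Going by these compounds alone, no step from compound 1, compound 2 or compound 3 to compound 4 can be read, because the read-out stops at one value: the limit of > 20000 nM in this assay, at which 3 of the 4 values shown sit. The compounds shown leave open whether compound 2, compound 3 and compound 4 differ from one another in cytotoxicity at all.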